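The source may hold more compounds than are shown below. What is called first, only, known or untested is meant among the compounds shown, and "the series" means these compounds.

Measured compounds:
- compound 1 `O=C(/C=C/c1ccc(/C=N/NC(=O)c2ccncc2)cc1)c1cccc(Br)c1`: 14%
- compound 2 `O=C(N/N=C/c1ccc(/C=C/C(=O)c2ccccc2F)cc1)c1ccncc1`: 51.3%
- compound 3 `N=C(N)N/N=C/c1ccc(/C=C/C(=O)c2ccc(Cl)cc2)cc1`: 56.4%

In a functional assay on the whole organism (Ear) for inhibition, with Mus musculus as the target, with a stated time of 30 min, at a dose of 100 mg/kg by the intraperitoneal route (on this read-out higher numbers stand for more inhibition at the one dose given (going by the name of the read-out) and lower numbers for less inhibition), compound 3 gives the largest number among the three, but compound 2 lies within the scatter of it, so the two cannot be ranked; compound 1 sits clearly beyond the scatter below both. Compound 4 `N=C(N)N/N=C/c1ccc(/C=C/C(=O)c2ccccc2Br)cc1` is obtained from compound 3 by one change: 2-bromophenyl in place of 4-chlorophenyl on a carbonyl carbon. Among the compounds with values here, the one measured step touching the same place is a number 37.3 percentage points higher from compound 1 to compound 2 (beyond the scatter), which swapped one halophenyl for another on the carbonyl carbon, though the core there differed from that of compound 3. That step was large, so a change in either direction is possible here, and no clear direction can be read. The step from compound 3 to compound 4 is expected to be a number 9.4 percentage points lower from compound 3 to compound 4 (within the scatter). Compound 4 is therefore estimated at 47%, within 22% to 70%.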

Compound 4, a percentage reported as inhibition, in the whole organism at one dose (the size of the read-out at that dose, not a potency): 78.3%
Beside the measured number, compound 4's estimate is 31.3 percentage points below it; measured number outside the range, above it.
By their numbers in this assay, from the lowest: compound 1; then compounds 2 and 3 (each within the scatter of the next); then compound 4.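

With the rest of the molecule unchanged, putting 2-bromophenyl in place of 4-chlorophenyl on a carbonyl carbon gives a number 21.9 percentage points higher from compound 3 to compound 4 (beyond the scatter) in this assay. The halophenyl at this place therefore still shifts the read-out on the core of compound 3, not only on the core of compound 1 and compound 2. No measurement offers an explanation for this rise.

The halogen and its ring position changed together, and the two cannot be separated here. Going by these compounds, how an unsubstituted phenyl or a methoxyphenyl would fare at this place also remains open.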